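The source may hold more compounds than are shown below. What is called first, only, known or untested is meant among the compounds shown, and "the series" means these compounds.

Compound 1 `CC(C)Nc1ccc(-c2ccn3c(CC4CC4)nnc3c2Cl)cc1F` gives 224 nM in a functional assay on cells for positive allosteric modulation of metabotropic glutamate receptor 2 (Homo sapiens), read by scintillation counting and GTPgammaS binding, with a stated time of 30 min; on this read-out lower numbers stand for an effect already at smaller amounts and higher numbers for an effect only at larger amounts of compound. Compound 2 `CC(C)Nc1ccc(-c2ccn3c(CC4CC4)nnc3c2C(F)(F)F)cc1F` gives 93.3 nM in this assay, the change being a 2.4-fold lower number from compound 1 to compound 2 (0.38 log units; beyond the scatter). On these two numbers compound 2 stands lowest, with compound 1 the nearest to it. Compound 3 `COc1ccc(COc2ccc(-c3ccn4c(CC5CC5)nnc4c3C(F)(F)F)cc2F)cn1` carries (6-methoxypyridin-3-yl)methoxy in place of isopropylamino on an aromatic carbon. Within the data shown here, no measured step touches this part of the molecule: the single known step, a 2.4-fold lower number from compound 1 to compound 2 (0.38 log units; beyond the scatter), concerns the trifluoromethyl group that compound 3 keeps, so it gives no direction for the present change. The expected step is a 1.1-fold higher number from compound 2 to compound 3 (0.03 log units; within the scatter), no more than the scatter. For compound 3 the estimate in this assay is 100 nM, with a range from 25 nM to 400 nM.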

Compound 3, half-maximal effective concentration: 40.7 nM
For compound 3 the middle estimate is 2.5-fold (0.39 log units) above the measured one; measured number inside the range.
By their numbers in this assay, from the lowest: compound 3; then compound 2; then compound 1.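

In this assay, the aromatic carbon ortho to a fluoro group accepts a far larger group than isopropylamino: (6-methoxypyridin-3-yl)methoxy gives a 2.3-fold lower number from compound 2 to compound 3 (0.36 log units; beyond the scatter), with the trifluoromethyl group kept. The hydrogen-bond donor of isopropylamino is thus not required for a low number at this position. No measured evidence bears on why the number moves.

Which part of the entering group matters remains open, as its ring, ring nitrogen, methoxy and linking oxygen all arrive together. A plain benzyloxy group, or a benzylamino group, would begin to separate these parts.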